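This account rests on a few compounds, and the source may have more. Where it says the series, first, only, none or still open, it means among the compounds named here.

Working notes on the series in a functional assay on U-87MG ATCC cells for inhibition, with U-87 MG (Homo sapiens) as the target, read by MTT assay, with a stated time of 72 h; on this read-out higher numbers stand for weaker inhibition and lower numbers for stronger inhibition. Compound 1 `Cc1ccnc(NC(c2ccc(C(F)(F)F)cc2)c2ccc3cccnc3c2O)c1` gives 2100 nM. Compound 2 `COc1ccc(C(Nc2cc(C)ccn2)c2ccc3cccnc3c2O)cc1O` reads > 10000 nM, which is a limit and not a number. Compound 3 `Cc1ccnc(NC(c2ccc(F)cc2)c2ccc3cccnc3c2O)c1` reads > 10000 nM, also a limit. Compound 3 therefore stands at the limit of > 10000 nM in this assay, at which 2 of the 3 values shown sit.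

The next change leads to compound 4 `Cc1ccnc(NC(c2ccc3cccnc3c2O)c2c(F)cccc2Cl)c1`: 2-chloro-6-fluorophenyl in place of 4-fluorophenyl on a saturated chain carbon bound to an aromatic carbon and a nitrogen on an aromatic ring. Here 2-chloro-6-fluorophenyl takes the place of 4-fluorophenyl on a saturated chain carbon bound to an aromatic carbon and a nitrogen on an aromatic ring.

Two measured steps alter this same group and both lie beyond the scatter: an at least 4.7-fold higher number from compound 1 to compound 3 (0.67 log units; beyond the scatter) and an at least 4.7-fold higher number from compound 1 to compound 2 (0.67 log units; beyond the scatter). The third, a step that the two limits leave unreadable from compound 2 to compound 3, gives no size. Among the compounds with values here, no measured compound carries 2-chloro-6-fluorophenyl, so the size of the change rests on weak ground, and only compound 1 has given a number so far.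

A modest move toward stronger inhibition is expected, written as an at least 1.4-fold lower number from compound 3 to compound 4 (0.15 log units; that floor lies within the scatter), and another limit reading remains quite possible. For compound 4 the estimated value is 7000 nM, with an expected range of 2500 nM to 20000 nM.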

Compound 4, half-maximal inhibitory concentration: 20600 nM
Estimate against measurement, compound 4: 2.9-fold (0.47 log units) below; measured number outside the range, above it.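

In this assay, the step with 2-chloro-6-fluorophenyl is a 9.8-fold higher number from compound 1 to compound 4 (0.99 log units; beyond the scatter), which gives this position a second exact number and a readable size for a change of this aryl group. Compound 1 remains the strongest of the four, as its steps to compound 2, compound 3 and compound 4 are all printed as beyond the scatter. The steps from compound 2 and from compound 3 to compound 4 cannot be read, since each of those two compounds rests on a limit: the limit of > 10000 nM in this assay, at which 2 of the 4 values shown sit.

Still open, from the compounds shown here alone, is whether a nitrile or a pentafluorosulfanyl group in place of trifluoromethyl on the aromatic carbon would hold the number of compound 1. Going by these compounds, the effect of an amine or a carboxylic acid on that phenyl ring also remains open.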